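Adding a (dimethylamino)methyl arm to the plain ketone

The source may hold more compounds than are shown below. What is called first, only, known or untested is meant among the compounds shown, and "the series" means these compounds.

Of the compounds shown here, three have been measured in a functional assay on P388 cells (Mus musculus); on this read-out higher numbers stand for weaker inhibition and lower numbers for stronger inhibition. Among the measured compounds shown here, compound 1 `Cc1ccc(/C=C/C(=O)Oc2ccc(/C=C3\CCCC(CN(C)C)C3=O)cc2)cc1` gives 1290 nM and compound 2 `COc1ccc(/C=C/C(=O)Oc2ccc(/C=C3\CCCC(CN(C)C)C3=O)cc2)cc1` gives 2410 nM; the one step between them, a 1.9-fold higher number from compound 1 to compound 2 (0.27 log units; within the scatter), does not rise above the scatter. Compound 3 `O=C1CCCC/C1=C\c1ccc(OC(=O)c2ccc(Cl)cc2)cc1`, which carries a different ester and lacks the amine-bearing arm of the other two, gives 25500 nM; this is the highest number of the three, and both gaps to compounds 1 and 2 lie beyond the scatter, so compound 3 is the weakest inhibitor measured so far.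

Compound 4 `CN(C)CC1CCC/C(=C\c2ccc(OC(=O)c3ccc(Cl)cc3)cc2)C1=O` differs from compound 3 by (dimethylamino)methyl in place of hydrogen on a saturated ring carbon. For the measured compounds named here, no measured pair isolates this change: compounds 1 and 2 differ from compound 3 in the ester as well as in this arm, so their lower numbers can only hint, not prove, that the arm helps. On that hint, the number for compound 4 is expected to fall, a 7.3-fold lower number from compound 3 to compound 4 (0.86 log units; beyond the scatter), with wide uncertainty because the ester also differs in compounds 1 and 2. Compound 4 is therefore estimated at 3500 nM, within a range of 900 nM to 14000 nM.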

Compound 4, half-maximal inhibitory concentration: 425 nM
The estimate for compound 4 lay 8.2-fold (0.92 log units) above the measured number; the measured number lies below the stated range.
By their numbers in this assay, from the lowest: compound 4; then compounds 1 and 2 (each within the scatter of the next); then compound 3.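

In this assay, among the compounds shown here, the (dimethylamino)methyl arm can now be judged with the ester held fixed: replacing hydrogen on a saturated ring carbon with this arm gives a 60-fold lower number from compound 3 to compound 4 (1.78 log units; beyond the scatter) as the only structural change. With the arm present, the ester also counts, as 4-chlorophenyl in place of 2-(4-methoxyphenyl)ethenyl gives a 5.7-fold lower number from compound 2 to compound 4 (0.75 log units; beyond the scatter) and 4-chlorophenyl in place of 2-(4-methylphenyl)ethenyl gives a 3.0-fold lower number from compound 1 to compound 4 (0.48 log units; beyond the scatter) on the same carbonyl carbon. Nothing available explains why either change has this effect.

The compounds shown do not separate the nitrogen from the carbon chain that holds it, so a plain ethyl group on that ring carbon would be informative. Nor do they show whether a primary amine, a morpholine or a longer chain ending in dimethylamino would match this arm.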